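A Diethylamino Chain Replaces the Primary Amine

This account rests on a few compounds, and the source may have more. Where it says the series, first, only, none or still open, it means among the compounds named here.

In a functional assay on HL-60 cells (Homo sapiens) for antiproliferative activity, read by MTT assay, with a stated time of 24 h (on this read-out lower numbers stand for stronger inhibition and higher numbers for weaker inhibition), compound 3 `COc1cc(Nc2ncc(I)c(NCCCN)n2)cc(OC)c1OC` gives 43400 nM, the higher of the two true numbers. Compound 1 `CNC(=O)c1ccccc1Oc1nc(Nc2cccc(C(C)C)c2)ncc1Br` gives 17500 nM, a gap beyond the scatter. Compound 2 `COc1cc(Nc2nccc(NCCCN)n2)cc(OC)c1OC` reads > 50000 nM, which is a limit of the assay and not a number. Within the data shown here, the only measured step is an at least 1.1-fold lower number from compound 2 to compound 3 (0.06 log units; that floor lies within the scatter), for iodo in place of hydrogen on an aromatic carbon, and it does not touch the chain. Compound 4 `CCN(CC)CCNc1nc(Nc2cc(OC)c(OC)c(OC)c2)ncc1I` changes that chain: diethylamino in place of aminomethyl on a saturated chain carbon, two bonds along the chain from a nitrogen on an aromatic ring, with 3-aminopropyl becoming 2-(diethylamino)ethyl. Among the measured compounds shown here, no measured step covers this change, so the expectation rests on compound 3 at 43400 nM, and no shift beyond the scatter is expected in this assay. The estimated change is a 1.4-fold lower number from compound 3 to compound 4 (0.16 log units; within the scatter). Compound 4 is expected at 30000 nM, with an estimated range of 10000 nM to 60000 nM.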

Compound 4, half-maximal inhibitory concentration: 21600 nM
For compound 4 the middle estimate is 1.4-fold (0.14 log units) above the measured one, and the stated range covers the measured number.
By their numbers in this assay, from the lowest: compounds 1, 4 and 3 (each within the scatter of the next, the first and the last beyond it). At a limit, above all of these: compound 2.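

In this assay, 2-(diethylamino)ethyl in place of 3-aminopropyl gives a 2.0-fold lower number from compound 3 to compound 4 (0.30 log units; within the scatter), so this change on the chain moves the number no further than the scatter. The position takes diethylamino, with its 0 hydrogen-bond donors, in place of aminomethyl and still gives a true number. Unlike the earlier step, this one joins two true numbers, since only compound 2 reads at a limit: the limit of > 50000 nM in this assay, at which 1 of the 4 values shown sits.

Still open, going by these compounds, is whether a morpholine or a piperidine at the chain end, or a longer chain, would read differently. Also open, on these data alone, is how the diethylamino chain reads with hydrogen in place of iodo.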